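The source may report more compounds than this note shows. Statements on the series, on what has been measured and on what is new or still open speak of the compounds shown alone.

Measured so far in a functional assay on HUVEC cells (Homo sapiens) for inhibition, using NADPH, with a stated time of 2 h; a higher number here means a weaker inhibitor, a lower number a stronger inhibitor:
Compound 1 `Cc1ccc2[nH]c(COc3cccc(OCC4CCOCC4)c3)c(C)c(=O)c2c1`: 38 nM
Compound 2 `Cc1c(COc2cccc(OCC3CCOCC3)c2)[nH]c2ccc(Br)cc2c1=O`: 23 nM
Compound 3 `Cc1c(COc2cccc(OCC3CCOCC3)c2)[nH]c2ccc(C(=O)O)cc2c1=O`: 400 nM

Compound 3 has the highest number of the three, which makes it the weakest inhibitor here. Its gaps to the other two are large: an 11-fold higher number from compound 1 to compound 3 (1.02 log units; beyond the scatter) and a 17-fold higher number from compound 2 to compound 3 (1.24 log units; beyond the scatter). All three share one core and differ only in a single group on an aromatic carbon.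

Compound 4 `Cc1c(COc2cccc(OCC3CCOCC3)c2)[nH]c2ccc(-c3cccnc3)cc2c1=O` has not been measured yet. It has pyridin-3-yl in place of carboxy on that same carbon: pyridin-3-yl in place of carboxy on an aromatic carbon.

Within the data shown here, no measured compound has a ring at this place, so the evidence is indirect. Exchanging the two non-acid groups changed little, with a 1.7-fold lower number from compound 1 to compound 2 (0.22 log units; within the scatter), which is within the scatter. Only the arrival of carboxy gave a large step, in both measured cases. Compound 4 gives up that carboxy, so in this assay a step of similar size in the opposite direction is expected, towards a lower number. From the compounds shown here alone, the new ring is untested, so the expected range is kept wide.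

The estimated change is a 10-fold lower number from compound 3 to compound 4 (1.00 log units; beyond the scatter). The expected value for compound 4 is 40 nM, with an estimated range of 12 nM to 130 nM.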

Compound 4, half-maximal inhibitory concentration: > 10000 nM
Compound 4: only a limit was reported; the forecaster's own chance of this, stated with the estimate: 3%; at least 250-fold (2.39 log units) between middle value and limit.
By their numbers in this assay, from the lowest: compounds 2 and 1 (each within the scatter of the next); then compound 3. At a limit, above all of these: compound 4.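

In this assay the result for compound 4 is a limit and not a number: the limit of > 10000 nM in this assay, at which 1 of the 4 values shown sits. Among these compounds, the earlier compounds left carboxy as the only group with a large cost at this place, yet pyridin-3-yl, the only ring here among the four compounds, gives an at least 25-fold higher number from compound 3 to compound 4 (1.39 log units; beyond the scatter). Its gaps to the two small groups are also large, with an at least 430-fold higher number from compound 2 to compound 4 (2.63 log units; beyond the scatter) and an at least 260-fold higher number from compound 1 to compound 4 (2.42 log units; beyond the scatter), so the outcome at this aromatic carbon depends on more than whether carboxy is present.

The compounds shown leave open whether the loss belongs to any ring at this carbon or to pyridin-3-yl in particular, a question that a phenyl ring, which has carbon only, or a pyridin-4-yl ring could help to settle. They also say nothing about how an amine, an amide or a longer carbon chain would fare here, so the range of groups accepted at this carbon remains unmapped beyond methyl, bromo, carboxy and pyridin-3-yl.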